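The source may hold more compounds than are shown below. What is called first, only, known or untested is meant among the compounds shown, and "the series" means these compounds.

Of the compounds shown here, three have been measured in a functional assay on T98G cells (Homo sapiens) for inhibition, read by colorimetric assay and MTT assay, with a stated time of 72 h; a higher number here means a weaker inhibitor, a lower number a stronger inhibitor. Compound 1 (`Cc1ccc2c(c1)-c1cnc(n1C)OCCCCCCCCO2`) gives 63000 nM, compound 2 (`C=CCCCCOc1ccccc1-c1cnc(OCCC=C)n1C`) gives 29000 nM, and compound 3 (`C=CCCCCOc1ccc(C)cc1-c1cnc(OCCC=C)n1C`) gives 94000 nM. The values of compound 1 and compound 3 lie within the scatter of each other, while compound 2 has the lowest number of the three. Among the compounds with values here, the single measured step in this small series is a 3.2-fold higher number from compound 2 to compound 3 (0.51 log units; beyond the scatter), with methyl in place of hydrogen on an aromatic carbon. Compound 4 (`C=CCCCCOc1ccc(OC)cc1-c1cnc(OCCC=C)n1C`) has methoxy in place of methyl on that carbon, para to a (hex-5-en-1-yl)oxy group: methoxy in place of methyl on an aromatic carbon. Within the data shown here, with a 3.2-fold higher number from compound 2 to compound 3 (0.51 log units; beyond the scatter) as the only modest guide, and no measured change from methyl to methoxy, no step beyond the scatter is expected in this assay. The estimated change is a 1.3-fold lower number from compound 3 to compound 4 (0.13 log units; within the scatter). Compound 4 is expected at about 70000 nM, with an estimated range from 28000 nM to 170000 nM.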

Compound 4, half-maximal inhibitory concentration: 74000 nM
Compound 4: the middle estimate sits 1.1-fold (0.02 log units) below what was measured, within the range that was stated.
By their numbers in this assay, from the lowest: compound 2; then compounds 1, 4 and 3 (each within the scatter of the next).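

In this assay, methoxy and methyl at this carbon, para to a (hex-5-en-1-yl)oxy group, are not told apart: the change gives a 1.3-fold lower number from compound 3 to compound 4 (0.10 log units; within the scatter) and so stays inside the usual variation. The earlier compounds shown here showed one group at this place raising the number over hydrogen; with a 2.6-fold higher number from compound 2 to compound 4 (0.41 log units; beyond the scatter) alongside a 3.2-fold higher number from compound 2 to compound 3 (0.51 log units; beyond the scatter), a second group now does so, and in both cases the step lies beyond the scatter. No evidence is available that explains this result.

The compounds shown leave open whether this rise holds for groups of another kind at this carbon, such as an amine, a carboxylic acid or a fluorine atom. They also leave open whether a longer chain on the oxygen in place of methoxy would keep the number where it is.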